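The source may hold more compounds than are shown below. What is called first, only, known or untested is meant among the compounds shown, and "the series" means these compounds.

Three compounds from this series carry a number in a physicochemical assay for lipophilicity, read by HPLC; on this read-out higher numbers stand for higher lipophilicity and lower numbers for lower lipophilicity. Compound 1 `CCn1c(-c2cnc(C)nc2)nc2c(N[C@H]3CCN(C(=O)C4CCC4)C3)ncnc21` gives 1.2 in this assay, compound 2 `CCn1c(-c2cnc(C)nc2)nc2c(N[C@H]3CCN(C(=O)c4cocn4)C3)ncnc21` gives 0.6, and compound 3 `CCn1c(-c2cnc(C)nc2)nc2c(O[C@H]3CCN(C(=O)C4CC(F)(F)C4)C3)ncnc21` gives 1.5. Compound 2 therefore stands lowest of the three, with compound 1 nearest to it and compound 3 furthest away, both gaps beyond the scatter.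

The step under consideration leads from compound 2 to compound 4 `CCC(=O)N1CC[C@H](Nc2ncnc3c2nc(-c2cnc(C)nc2)n3CC)C1`, which is still to be measured in this assay. The change is ethyl in place of 1,3-oxazol-4-yl on a carbonyl carbon. Going by the values given here, one measured step bears on it: the change with 1,3-oxazol-4-yl in place of cyclobutyl on a carbonyl carbon gave a number 0.60 log units lower from compound 1 to compound 2 (beyond the scatter). The step to compound 4 runs the other way, removing the 1,3-oxazol-4-yl and bringing in ethyl, a group with fewer heavy atoms than cyclobutyl. A rise in this assay is therefore expected, though likely smaller than the full return to the number of compound 1.

On this basis compound 4 is expected to reach about 0.9 in this assay, with a range of 0.5 to 1.3. The estimated step is a number 0.30 log units higher from compound 2 to compound 4 (within the scatter), expected to be upward and beyond the scatter.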

Compound 4, distribution coefficient: 0.7
Compound 4: middle estimate off by 0.20 log units, on the high side, and the stated range covers the measured number.
By their numbers in this assay, from the lowest: compounds 2 and 4 (each within the scatter of the next); then compounds 1 and 3 (each within the scatter of the next).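

In this assay, ethyl in place of 1,3-oxazol-4-yl on a carbonyl carbon gave a number 0.10 log units higher from compound 2 to compound 4 (within the scatter), so at this position the two groups cannot be told apart, even though ethyl has no ring and no hydrogen-bond acceptors. Ethyl in place of cyclobutyl gave a number 0.50 log units lower from compound 1 to compound 4 (beyond the scatter), which shows that the earlier gap between compound 1 and compound 2 is not specific to 1,3-oxazol-4-yl: among these three compounds, which differ only in this group, cyclobutyl alone stands apart. No measurement at hand explains why these groups read as they do.

As far as these compounds go, whether a longer chain such as propyl, or a smaller ring such as cyclopropyl, would stay level with compound 4 or come closer to compound 1 remains open, and with only these groups the trend cannot be tied to ring, chain length or atom count. Compound 3 differs from each of these compounds in more than one place, so the steps to it cannot be read, and it remains open whether ethyl would give a similar step on a compound with the ring joined through oxygen.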